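Carboxylic Acid Replacing Chlorine on a Distal Pyrazole

The compounds below may be only part of what the source reports. "The series", "measured", "known", "first", "only" and "open" are said of these compounds alone.

Compound 1, `C[C@@H]1CN(c2sc(C(F)(F)F)nc2-c2nc3ccccc3[nH]2)CCN1C(=O)Cn1cc(Cl)cn1`: 1.7 nM in a functional assay on CHO-K1 cells for antagonist activity at C-X-C chemokine receptor type 3 (Homo sapiens), read by FLIPR, with a stated time of 10 min, in the presence of a further agent that is not named here; on this read-out higher numbers stand for weaker inhibition and lower numbers for stronger inhibition
Compound 2, `Cc1nc(C)n(CC(=O)N2CCN(c3sc(C(F)(F)F)nc3-c3nc4c(C(F)(F)F)cccc4[nH]3)C[C@H]2C)n1`: 6 nM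
Compound 3, `Cc1nc(C)n(CC(=O)N2CCN(c3sc(C(F)(F)F)nc3-c3nc4ccc(C(C)(C)O)c(F)c4[nH]3)C[C@H]2C)n1`: 9.4 nM

Of the three measured compounds, compound 1 gives the lowest number in this assay. The gap to compound 2 lies beyond the usual scatter, and the larger gap to compound 3 lies further beyond it, so compound 1 is the strongest inhibitor of the set.

Compound 4, `C[C@@H]1CN(c2sc(C(F)(F)F)nc2-c2nc3ccccc3[nH]2)CCN1C(=O)Cn1ccc(C(=O)O)n1`, keeps the core of compound 1 and differs from it only in the group on the amide-bearing chain: 3-carboxy-1H-pyrazol-1-yl in place of 4-chloro-1H-pyrazol-1-yl on a saturated chain carbon bound to a carbonyl carbon

For the measured compounds named here, no measured pair in this set carries this change, so its effect is not anchored by a neighbouring step. An acid entering where a chlorine left is expected to weaken inhibition moderately, beyond the scatter. The step of a 3.5-fold higher number from compound 1 to compound 4 (0.55 log units; beyond the scatter) is what this estimate implies. Compound 4 is expected to give 6 nM in this assay, with a range from 1.5 nM to 25 nM.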

Compound 4, half-maximal inhibitory concentration: 2100 nM
Estimate against measurement, compound 4: 350-fold (2.54 log units) below; the measured number lies above the stated range.
By their numbers in this assay, from the lowest: compound 1; then compounds 2 and 3 (each within the scatter of the next); then compound 4.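

In this assay the exchange of 4-chloro-1H-pyrazol-1-yl for 3-carboxy-1H-pyrazol-1-yl on a saturated chain carbon bound to a carbonyl carbon gives a 1200-fold higher number from compound 1 to compound 4 (3.09 log units; beyond the scatter) with the shared core unchanged. For the compounds shown here, this is the first one-place comparison in the set, and it shows that inhibition at this position depends heavily on the group carried there. No measurement shown explains the size of this step.

The compounds shown leave open whether the step follows from the carboxylic acid itself or from where it sits on the pyrazole. A methyl ester or a primary amide on the same pyrazole, or 4-carboxy-1H-pyrazol-1-yl, would bear on that question.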